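Amine-Bearing Ring Replaces a Hydroxyalkyl Group on Sulfur

The source may hold more compounds than are shown below. What is called first, only, known or untested is meant among the compounds shown, and "the series" means these compounds.

Of the compounds shown here, three sharing one core have been measured in a functional assay on HT cells (Homo sapiens) for antiproliferative activity, read by fluorescence, with a stated time of 72 h; a lower number here means a stronger inhibitor of growth, a higher number a weaker inhibitor of growth. Compound 1 `CC(C)c1n[nH]c2c(NCc3ccc(-c4ccccn4)cc3)nc(SCC(O)CO)nc12` gives 21 nM in this assay. Compound 2 `CC(C)c1n[nH]c2c(NCc3ccc(-c4ccccn4)cc3)nc(SC(C)C(C)O)nc12` gives 190 nM, and compound 3 `CC(C)c1n[nH]c2c(NCc3ccc(-c4ccccn4)cc3)nc(SCCn3ccnc3)nc12` gives 155 nM. Compound 2 thus carries the highest number of the three: the step of a 9.0-fold higher number from compound 1 to compound 2 (0.96 log units; beyond the scatter) lies beyond the scatter, while the step of a 1.2-fold lower number from compound 2 to compound 3 (0.09 log units; within the scatter) lies within it, so compounds 2 and 3 cannot be separated on these numbers.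

Compound 4 `CC(C)c1n[nH]c2c(NCc3ccc(-c4ccccn4)cc3)nc(SC3CCCCC3N)nc12` differs from compound 2 at the sulfur: 2-aminocyclohexyl in place of 2-hydroxy-1-methylpropyl on a sulfur. Going by the values given here, no measured step exchanges a hydroxy group for an amine or introduces a six-membered non-aromatic ring, so none bears directly on this change. What the measured steps do show is how far the group on the sulfur can move the number: a 9.0-fold higher number from compound 1 to compound 2 (0.96 log units; beyond the scatter) and a 7.4-fold higher number from compound 1 to compound 3 (0.87 log units; beyond the scatter) are both sizeable, whereas a 1.2-fold lower number from compound 2 to compound 3 (0.09 log units; within the scatter) does not leave the scatter. The change from compound 2 to compound 4 is larger than either of those, so a step of comparable size in either direction is possible, and no direction is secured by the data. Compound 4 is therefore expected to fall inside the range spanned by the three measured compounds, with an expected step of a 1.9-fold lower number from compound 2 to compound 4 (0.28 log units; within the scatter). The estimated value for compound 4 is 100 nM, with a range from 25 nM to 400 nM.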

Compound 4, concentration for 50% growth inhibition: 139 nM
Estimate against measurement, compound 4: 1.4-fold (0.14 log units) below, within the range that was stated.
By their numbers in this assay, from the lowest: compound 1; then compounds 4, 3 and 2 (each within the scatter of the next).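

In this assay, replacing the open 2-hydroxy-1-methylpropyl with 2-aminocyclohexyl on a sulfur gives a 1.4-fold lower number from compound 2 to compound 4 (0.14 log units; within the scatter), so a group with one six-membered non-aromatic ring of carbon only and an amine in place of the hydroxy group leaves the number where compound 2 had it. Compound 4 also cannot be separated from the imidazole-bearing compound, with a 1.1-fold lower number from compound 3 to compound 4 (0.05 log units; within the scatter), so three quite different groups on this sulfur now give numbers that lie within the scatter of one another. Going by these compounds alone, the 2,3-dihydroxypropyl of compound 1 remains the one group that stands apart, with a 6.6-fold higher number from compound 1 to compound 4 (0.82 log units; beyond the scatter), and this adds a third group to those whose steps from compound 1 lie beyond the scatter.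

Still open, as far as these compounds go, is whether the ring or the amine matters on its own, since 2-hydroxycyclohexyl or an open-chain 2-aminopropyl on the sulfur would separate the two, and whether a ring with two hydroxy groups, such as 2,3-dihydroxycyclohexyl, would approach compound 1. Nothing available here explains why these groups give such similar numbers or why compound 1 stands apart.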